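Swapping the Thiazole for a Pyrimidine on Sulfur

The compounds below may be only part of what the source reports. "The series", "measured", "known", "first", "only" and "open" are said of these compounds alone.

Compound 1 `Cn1nc(-c2cccnc2)c2ccccc2c1=O`: 63%
Compound 2 `O=c1c2ccccc2c(-c2cccnc2)nn1CCSc1nccs1`: 97%

In an assay on isolated protein (Oryctolagus cuniculus) with Thromboxane-A synthase (Homo sapiens) as the target, tested at 1 uM (on this read-out lower numbers stand for less inhibition and higher numbers for more inhibition at the one concentration tested (going by the name of the read-out)), compound 1 gives 63%, and compound 2 gives 97%. Compound 2 stands highest of the two numbers, its nearest neighbour being compound 1, and the step of a number 34 percentage points higher from compound 1 to compound 2 (beyond the scatter) is large. Compound 3 `O=c1c2ccccc2c(-c2cccnc2)nn1CCSc1ncccn1` differs from compound 2 in one place: pyrimidin-2-yl in place of 1,3-thiazol-2-yl on a sulfur. Among the compounds with values here, no measured step touches the ring on the sulfur; the step of a number 34 percentage points higher from compound 1 to compound 2 (beyond the scatter) shows only that adding the whole side chain raised inhibition. The expected step is therefore small, a number 9 percentage points lower from compound 2 to compound 3 (within the scatter). For compound 3 the estimate is 88%, in the range 65% to 99%.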

Compound 3, a percentage reported as inhibition, at one concentration (the size of the read-out at that concentration, not a potency): 86%
Compound 3: middle estimate off by 2 percentage points, on the high side, within the range that was stated.
By their numbers in this assay, from the lowest: compound 1; then compound 3; then compound 2.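

In this assay, within the data shown here, the ring on the sulfur turns out to count: pyrimidin-2-yl in place of 1,3-thiazol-2-yl gives a number 11 percentage points lower from compound 2 to compound 3 (beyond the scatter), a change the earlier compounds could not show. The side chain still pays with the new ring, at a number 23 percentage points higher from compound 1 to compound 3 (beyond the scatter), so its gain does not depend on 1,3-thiazol-2-yl alone. Nothing available explains the difference between the two rings.

As far as these compounds go, whether a phenyl ring on the sulfur, a carboxylic acid or a longer chain would keep inhibition this high remains open. Single-concentration percentages also leave the potencies of these compounds open.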